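The source may hold more compounds than are shown below. What is called first, only, known or untested is meant among the compounds shown, and "the series" means these compounds.

Working notes on the series, read out in a functional assay on the whole organism (strain Sprague-Dawley) for inhibition, with Rattus norvegicus as the target, with a stated time of 10 min; a lower number here means that less compound is needed, a higher number that more compound is needed for the effect. Compound 1 `CSc1ccccc1-c1ncc(C(=O)O)c(=O)[nH]1` gives > 20 mg/kg, which is a limit and not a number. Compound 2 `CC1Cc2cccc(-c3ncc(C(=O)O)c(=O)[nH]3)c2O1` gives 5 mg/kg. Compound 3 `CCOc1ccc(Cl)cc1-c1ncc(C(=O)O)c(=O)[nH]1` gives 0.5 mg/kg, the lowest of the two actual numbers, and compound 2 is its nearest neighbour, with a higher number beyond the scatter.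

The next change puts carboxy in place of chloro on an aromatic carbon, para to an ethoxy group, and leads to compound 4 `CCOc1ccc(C(=O)O)cc1-c1ncc(C(=O)O)c(=O)[nH]1`: carboxy in place of chloro on an aromatic carbon. Among the measured compounds shown here, no measured pair shows this change, so the expectation is loose. It rests mainly on compound 3 at 0.5 mg/kg already holding the lowest number, which leaves more room for movement upward than downward. A move to a higher number in this assay, probably beyond the scatter, is expected, with an estimated size of a 6.0-fold higher number from compound 3 to compound 4 (0.78 log units; beyond the scatter). For compound 4 the estimated dose is 3 mg/kg, with an expected range of 0.5 mg/kg to 20 mg/kg.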

Compound 4, dose for 50% inhibition: 25 mg/kg
For compound 4 the middle estimate is 8.3-fold (0.92 log units) below the measured one; measured number above the stated range.
By their numbers in this assay, from the lowest: compound 3; then compound 2; then compound 4.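

In this assay, among the compounds shown here, carboxy in place of chloro gives a 50-fold higher number from compound 3 to compound 4 (1.70 log units; beyond the scatter), the first step that can be read at a single place. The aromatic carbon para to an ethoxy group is therefore not indifferent to what it carries: chloro there goes with the lowest number in the series, while carboxy there calls for far more compound. This single pair cannot separate the parts of the change, such as the added heavy atoms and the added hydrogen-bond donor, so the step belongs to the exchange as a whole.

Compound 1 holds a limit and not a number, and no step to it can be read: the limit of > 20 mg/kg in this assay, at which 1 of the 4 values shown sits.
Open, on these data alone, is whether fluoro, an amine or a methyl ester at this position would stay closer to compound 3 or to compound 4, and whether the step would hold with a methoxy group in place of the ethoxy group.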